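The source may hold more compounds than are shown below. What is called first, only, known or untested is meant among the compounds shown, and "the series" means these compounds.

Measured compounds:
compound 1 `COc1ccc(F)cc1CNCCCNc1ccnc2cc(CC(C)C)ccc12` — 2900 nM
compound 2 `COc1cccc(CNCCCNc2ccnc3cc(CC(C)C)ccc23)c1O` — 2920 nM

In an ADME assay on HepG2 cells (Homo sapiens) for cytotoxicity, read by luminescence, CellTiter-Glo and ATP content, with a stated time of 72 h (a lower number here means that less compound is needed, a higher number that more compound is needed for the effect), compound 1 gives 2900 nM, the lowest of the two numbers, with compound 2 nearest at 2920 nM. Among the compounds with values here, the one measured step, a 1.0-fold higher number from compound 1 to compound 2 (0.00 log units; within the scatter), changed the group on the saturated chain carbon bound to an amine nitrogen and left the number unchanged within the scatter. Compound 3 `COc1ccc(F)cc1CNCCCNc1ccnc2cc(CC3CCCCC3)ccc12` is not yet measured. It differs from compound 1 at the other end of the shared core: cyclohexyl in place of isopropyl on a saturated chain carbon bound to an aromatic carbon. Within the data shown here, no measured step touches this position, so the step from compound 1 to compound 2 only shows that the other side of the core tolerates change without moving the number. For compound 3 a small step toward a lower number is expected, a 1.6-fold lower number from compound 1 to compound 3 (0.21 log units; within the scatter), with considerable uncertainty. Compound 3 is therefore estimated at 1800 nM, in the range 600 nM to 5000 nM.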

Compound 3, half-maximal effective concentration: 1830 nM
For compound 3 the middle estimate is 1.0-fold (0.01 log units) below the measured one; measured number inside the range.
By their numbers in this assay, from the lowest: compounds 3, 1 and 2 (each within the scatter of the next).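

In this assay, within the data shown here, cyclohexyl in place of isopropyl on a saturated chain carbon bound to an aromatic carbon gives a 1.6-fold lower number from compound 1 to compound 3 (0.20 log units; within the scatter) and so provides the first reading at this position. Compound 1 and compound 3 stay within the scatter of each other, so at this position a six-membered non-aromatic ring of carbon only is tolerated in the place of the open-chain isopropyl, much as the other end of the shared core tolerated the change between compound 1 and compound 2. Nothing measured here gives a reason for this result.

Going by these compounds, it remains open whether this position would read the same with an amine, a carboxylic acid or a longer chain in place of cyclohexyl. On these data alone, it is also open whether cyclohexyl would read the same alongside the 2-hydroxy-3-methoxyphenyl group of compound 2.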